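The source may hold more compounds than are shown below. What is called first, only, known or untested is meant among the compounds shown, and "the series" means these compounds.

Compound 1, with the structure `O=C(NCCCCn1cccn1)c1cccc(C2SCC(=O)N2c2ccccn2)c1`, gives 60.3 nM in a functional assay on HOS-TE85 cells (Homo sapiens) for inhibition, read by CCK-8 assay, with a stated time of 72 h; a lower number here means a stronger inhibitor, a higher number a weaker inhibitor. Compound 2, with the structure `O=C(NCCCCn1cccn1)c1cccc(C2SCC(=O)N2c2cc(Cl)ccn2)c1`, gives 36.4 nM in this assay. The difference between them is chloro in place of hydrogen on an aromatic carbon, and the step it makes is a 1.7-fold lower number from compound 1 to compound 2 (0.22 log units; within the scatter).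

Compound 3, with the structure `CC1SC(c2cccc(C(=O)NCCCCc3ccccc3)c2)N(c2cccc(C3CC3)c2)C1=O`, gives 295 nM in this assay. How its core differs from that of compound 1 is not broken down here. Compound 4, with the structure `CC1SC(c2cccc(C(=O)NCCCCc3ccc(Cl)cc3)c2)N(c2cccc(C3CC3)c2)C1=O`, is not yet measured; it differs from compound 3 by chloro in place of hydrogen on an aromatic carbon. This is the same kind of change as from compound 1 to compound 2, but not the same: there the chloro sits on a six-membered aromatic ring with one nitrogen, meta to a large group and opposite the ring nitrogen, whereas here it sits on a six-membered aromatic ring of carbon only, para to a large group. Since the earlier step of a 1.7-fold lower number from compound 1 to compound 2 (0.22 log units; within the scatter) stayed within the scatter, a comparably small step a 1.3-fold lower number from compound 3 to compound 4 (0.13 log units; within the scatter) is expected for compound 4. In this assay compound 4 is therefore estimated at 220 nM, likely between 100 nM and 500 nM.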

Compound 4, half-maximal inhibitory concentration: 932 nM
Compound 4: the middle estimate sits 4.2-fold (0.63 log units) below what was measured; the measured number lies above the stated range.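

In this assay the added chloro gives a 3.2-fold higher number from compound 3 to compound 4 (0.50 log units; beyond the scatter), so the weaker number for compound 4 is a real step, though a modest one. This change cannot be assumed to carry over from one core to another in this series, as the two steps differ: the same change on two cores in this assay, a 1.7-fold lower number (0.22 log units; within the scatter) from compound 1 to compound 2 and a 3.2-fold higher number (0.50 log units; beyond the scatter) from compound 3 to compound 4, 5.2-fold (0.72 log units) apart, beyond the scatter of two such steps. Among these compounds, the comparison does not show why they differ, since it rests on only two pairs and the chloro sits on a ring with one nitrogen in compound 2 but on a ring of carbon only in compound 4, while the cores differ in other places too.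

The compounds shown leave open how a fluoro, a methoxy or an amine at the same place on the 4-chlorophenyl ring would compare with the chloro. They also leave open whether chloro on the ring of carbon only would give a similar step on the core of compound 1.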